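The source may hold more compounds than are shown below. What is called first, only, known or untested is meant among the compounds shown, and "the series" means these compounds.

Measured so far:
Compound 1, `Cc1ccccc1Nc1nc(Nc2ccccc2)ncc1Cl`, gives > 100000 nM in a functional assay on MCF7 cells (Homo sapiens) for inhibition, read by CCK-8 assay, with a stated time of 48 h; a lower number here means a stronger inhibitor of growth, a higher number a weaker inhibitor of growth; that figure is a limit of the assay, not a number (the limit of > 100000 nM in this assay, at which 1 of the 3 values shown sits).
Compound 2, `Cc1ccccc1Nc1nc(Nc2ccc(N3CCN(C(=O)OC(C)(C)C)CC3)cc2)ncc1Cl`, gives 2250 nM in this assay.
Compound 3, `Cc1ccc(CNc2nc(Nc3ccc(N4CCN(C)CC4)cn3)ncc2Cl)cc1`, gives 38100 nM in this assay.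

Of the two compounds with a number, compound 3 stands at the higher one, and its gap from compound 2 lies beyond the scatter of repeated measurements. Compound 1 offers only a limit and does not enter the comparison. Going by the values given here, no pair among the measured compounds differs in one place alone, so no single step has been measured.

The account now follows the move from compound 3 to compound 4, `CC(C)c1cccc(Nc2nc(Nc3ccc(N4CCN(C)CC4)cn3)ncc2Cl)c1`. The change is 3-isopropylphenyl in place of 4-methylbenzyl on a nitrogen on an aromatic ring. Among the compounds shown, the two that carry an aryl group directly on that nitrogen, compound 1 and compound 2, give no common picture, so the step is estimated from compound 3 alone. Compound 4 is expected to move toward a lower number in this assay, with a step of a 6.4-fold lower number from compound 3 to compound 4 (0.80 log units; beyond the scatter) that lies beyond the scatter. The estimate for compound 4 is 6000 nM, within a range from 1200 nM to 30000 nM.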

Compound 4, concentration for 50% growth inhibition: 8640 nM
Compound 4: the middle estimate sits 1.4-fold (0.16 log units) below what was measured, and the stated range covers the measured number.
By their numbers in this assay, from the lowest: compound 2; then compound 4; then compound 3. At a limit, above all of these: compound 1.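

With 3-isopropylphenyl in place of 4-methylbenzyl on a nitrogen on an aromatic ring, the change gives a 4.4-fold lower number from compound 3 to compound 4 (0.64 log units; beyond the scatter) in this assay. Going by these compounds alone, this is the first single-place comparison, and it shows that the group at this position alters growth inhibition on an otherwise unchanged core, which the earlier compounds, with no such pair among them, could not show. Nothing measured here gives a reason for this step.

The compounds shown leave open how much of the step belongs to the change from a benzyl to a phenyl group and how much to the isopropyl group itself. As far as these compounds go, it also remains open how this nitrogen would respond to a longer chain such as phenethyl, or to a ring carrying a methoxy group or a carboxylic acid.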